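A few compounds are considered here, and "the series" means these few. Any claim that something is new, unique, unknown or untested is made for them only; others in the source may bear on it.

The series is built on a shared core carrying a methyl ester and an amine, with a different aromatic group on the pyridine side. Compound 1 is `COC(=O)c1sc2cc(-c3ccc(OC)nc3)cnc2c1N`, compound 2 is `COC(=O)c1sc2cc(-c3ccc4ccccc4c3)cnc2c1N`, compound 3 is `COC(=O)c1sc2cc(-c3ccc(C#N)cc3)cnc2c1N`, and the compound still to be tested, compound 4, is `COC(=O)c1sc2cc(-c3ccc(C(F)(F)F)cc3)cnc2c1N`.

In a functional assay on NCI-H460 cells (Homo sapiens) for inhibition, read by sulforhodamine B assay, with a stated time of 48 h (a lower number here means a stronger inhibitor of growth, a higher number a weaker inhibitor of growth), compound 2 gives 43500 nM. In this assay compound 1 gives > 37500 nM, which is a limit of the assay and not a number, as noted in the limit of > 37500 nM in this assay, at which 1 of the 3 values shown sits. In this assay compound 3 gives > 75000 nM, again a limit of the assay rather than a number, described in the limit of > 75000 nM in this assay, at which 1 of the 3 values shown sits. Compound 3 therefore stands at a limit, and of the three values shown two are limits; only compound 2 returns a number, itself high.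

The change from compound 3 to compound 4 is trifluoromethyl in place of cyano on an aromatic carbon. No measured pair among these compounds differs in a single place, so no measured step is available to size this change. Compound 3 gives > 75000 nM, which is a limit of the assay. Compound 2 gives 43500 nM. Compound 4 is therefore expected to remain a weak inhibitor of growth, with a step estimated as an at least 1.2-fold lower number from compound 3 to compound 4 (0.09 log units; that floor lies within the scatter). Compound 4 is estimated at 60000 nM, within a range from 20000 nM to 150000 nM.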

Compound 4, concentration for 50% growth inhibition: > 150000 nM
Compound 4: a limit, no number (the forecaster's own chance of this, stated with the estimate: 60%); at least 2.5-fold (0.39 log units) between middle value and limit.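

In this assay compound 4 gives > 150000 nM, which is a limit of the assay and not a number. Compound 3 also stands at a limit, so no step can be read between compound 3 and compound 4. The compounds shown leave open whether trifluoromethyl in place of cyano changes growth inhibition at all, and by how much.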